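The source may report more compounds than this note shows. Statements on the series, on what has been measured and on what is new or still open speak of the compounds shown alone.

Compound 1, with the structure `CCOC(=O)C1=Cc2ccccc2OC1(OCc1cn(CC(=O)Nc2ccccc2Br)nn1)C(F)(F)F`, is one of three compounds of a shared core tested in a functional assay on HeLa cells (Homo sapiens) for inhibition, read by MTT assay, with a stated time of 24 h; a lower number here means a stronger inhibitor, a higher number a weaker inhibitor. Compound 1 gives only a limit there, > 150000 nM, and not a number. Compound 2, `CCOC(=O)C1=Cc2ccccc2OC1(OCc1cc(-c2ccc(Br)cc2)no1)C(F)(F)F`, gives 52300 nM in this assay. Compound 3, `CCOC(=O)C1=Cc2ccccc2OC1(OCc1cc(-c2ccc3ccccc3c2)no1)C(F)(F)F`, again reaches only a limit in this assay, > 150000 nM. Among the compounds with values here, the one measured step is an at least 2.8-fold higher number from compound 2 to compound 3 (0.45 log units; beyond the scatter). On the numbers shown, compound 1 stands at the limit, and one further value shown is also a limit; this is described by the limit of > 150000 nM in this assay, at which 2 of the 3 values shown sit.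

Compound 4, `CCOC(=O)C1=Cc2ccccc2OC1(OCc1cn(-c2ccccc2)nn1)C(F)(F)F`, is not yet measured. It differs from compound 1 by phenyl in place of ((2-bromophenyl)carbamoyl)methyl on an aromatic nitrogen. Within the data shown here, no measured step touches this place: the step from compound 2 to compound 3 changes a group on an aromatic carbon of a different ring, so it does not bear on the change from compound 1 to compound 4. With compound 1 known only as a limit, the expected step is a number no higher from compound 1 to compound 4 (the limit leaves the size open), and no direction beyond the scatter can be claimed. Compound 4 is therefore estimated to give about 150000 nM in this assay, with a range from 50000 nM to 450000 nM, and a limit rather than a number is considered likely.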

Compound 4, half-maximal inhibitory concentration: > 150000 nM
Compound 4 ended at the assay's limit; the forecaster's own chance of this, stated with the estimate: 60%; the middle value sits exactly at the limit.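

Compound 1 and compound 4 both give only a limit in this assay, and no step can be read between them: the limit of > 150000 nM in this assay, at which 3 of the 4 values shown sit.

The compounds shown leave open how strongly either compound inhibits, and whether phenyl in place of ((2-bromophenyl)carbamoyl)methyl on an aromatic nitrogen changes the number at all.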